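The compounds below may be only part of what the source reports. "The series", "measured", "known", "first", "only" and "open" are said of these compounds alone.

Measured compounds in an assay on isolated protein for displacement of a labelled ligand from metabotropic glutamate receptor 5 (Homo sapiens), with a stated time of 60 min, tested at 1 uM; on this read-out lower numbers stand for less inhibition and higher numbers for more inhibition at the one concentration tested (going by the name of the read-out):

- compound 1, `CC1CCN(c2c(S(=O)(=O)c3ccc(F)c(Cl)c3)cnc3cc(F)ccc23)CC1`: 94%
- compound 2, `COc1cccc(S(=O)(=O)c2cnc3cc(F)ccc3c2N2CCC(C)CC2)c1`: 90%
- compound 3, `Cc1ccc(S(=O)(=O)c2cnc3cc(F)ccc3c2N2CCC(C)CC2)cc1Cl`: 93%

Compound 3 sits second highest of the three numbers in this assay . Its nearest neighbour is compound 1, with a number 1 percentage points lower from compound 1 to compound 3 (within the scatter), and its furthest is compound 2, with a number 3 percentage points higher from compound 2 to compound 3 (within the scatter). The third pairing, a number 4 percentage points lower from compound 1 to compound 2 (within the scatter), is likewise within the scatter. All three compounds share the same core and differ only in the aryl group on the sulfonyl sulfur, and none of those changes has moved the read-out beyond the usual spread of repeats.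

Compound 4, `Cc1ccc(S(=O)(=O)c2cnc3cc(F)ccc3c2N2CCC(C)CC2)cc1C`, has not been measured. Its difference from compound 3 is methyl in place of chloro on an aromatic carbon. This is a single-atom swap on the same aryl ring that the measured steps vary. Within the data shown here, the closest precedent is compound 1 to compound 3, a change of one substituent on that ring, which gave a number 1 percentage points lower from compound 1 to compound 3 (within the scatter); the larger ring replacements gave a number 4 percentage points lower from compound 1 to compound 2 (within the scatter) and a number 3 percentage points higher from compound 2 to compound 3 (within the scatter). Nothing in the measured steps points to a move in either direction, so the expected step for compound 4 in this assay is a number 2 percentage points lower from compound 3 to compound 4 (within the scatter), none beyond the scatter.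

Compound 4 is therefore estimated at 91% in this assay , with a range from 84% to 97%.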

Compound 4, a percentage reported as inhibition, at one concentration (the size of the read-out at that concentration, not a potency): 90%
Compound 4: middle estimate off by 1 percentage points, on the high side; the range from low to high includes it.
By their numbers in this assay, from the lowest: compounds 2, 4, 3 and 1 (each within the scatter of the next).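

In this assay, methyl in place of chloro on the aromatic carbon ortho to a methyl group gives a number 3 percentage points lower from compound 3 to compound 4 (within the scatter), so chloro is not needed at this position for the number to stay within the scatter. The 3,4-dimethylphenyl group also holds against the two other aryl groups on the sulfonyl sulfur, with no change at the digits printed from compound 2 to compound 4 (within the scatter) and a number 4 percentage points lower from compound 1 to compound 4 (within the scatter), which extends the flat picture to a ring carrying only methyl groups. No measurement is available that bears on why this change leaves the read-out flat.

All four numbers come from a single concentration in this assay and lie within the scatter of one another, so any difference in the size of the read-out at that concentration among these aryl groups cannot be read from them. Also open is whether the number in this assay stays level with a group of a different kind at this position, such as an amine, a carboxylic acid or a longer chain like propyl in place of the methyl, since every substituent shown here on the ring is small and uncharged.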